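Methylcarbamoyl to acetylsulfamoyl: a solubility question

The compounds below may be only part of what the source reports. "The series", "measured", "known", "first", "only" and "open" are said of these compounds alone.

Measured so far in a physicochemical assay for solubility, in phosphate buffer, measured as thermodynamic solubility, at pH 7.4; a lower number here means a less soluble compound, a higher number a more soluble compound:
- compound 1 `CS(=O)(=O)NC(=O)CCc1cn(-c2ccc(Br)cc2)nc1-c1ccc([N+](=O)[O-])cc1`: < 5000 nM
- compound 2 `CNC(=O)CCc1cn(-c2ccc(Br)cc2)nc1-c1ccc(Cl)cc1`: < 5000 nM

Compound 2 gives < 5000 nM, which is a limit of the assay and not a number. Compound 1 gives < 5000 nM, also a limit. Neither compound has an exact value, so they cannot be ranked: the limit of < 5000 nM in this assay, at which 2 of the 2 values shown sit.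

Compound 3 `CC(=O)NS(=O)(=O)CCc1cn(-c2ccc(Br)cc2)nc1-c1ccc(Cl)cc1` has not yet been measured. It carries acetylsulfamoyl in place of the methylcarbamoyl of compound 2, on a saturated chain carbon, two bonds along the chain from an aromatic carbon: acetylsulfamoyl in place of methylcarbamoyl on a saturated chain carbon, two bonds along the chain from an aromatic carbon. Going by the values given here, no measured pair shows what this change does. The assay may well report only a limit again. In this assay the expected change is a step that the limit leaves unreadable from compound 2 to compound 3, an estimate that stays within the usual scatter, with no direction favoured. For compound 3 the estimated solubility is 3000 nM, with an expected range from 800 nM to 15000 nM.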

Compound 3, solubility: 165000 nM
For compound 3 the middle estimate is 55-fold (1.74 log units) below the measured one; measured number outside the range, above it.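

Setting acetylsulfamoyl in place of methylcarbamoyl on a saturated chain carbon, two bonds along the chain from an aromatic carbon, gives an at least 33-fold higher number from compound 2 to compound 3 (1.51 log units; beyond the scatter) in this assay. Going by these compounds alone, compound 3 is the first compound here with an exact number, which shows that this single change, with the rest of the molecule left as it is, is enough to move a compound clear of the limit. The size of the step is a minimum and not an exact figure, because compound 2 stands at a limit: the limit of < 5000 nM in this assay, at which 2 of the 3 values shown sit.

The compounds shown do not tell why the step is so large, or whether it would hold on a different core. Going by these compounds, it also stays open whether a carboxylic acid at this place, or a longer chain carrying the acetylsulfamoyl, would give a similar number.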